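Swapping a Nitrile for a Cyano-Triazole on the Core

The source may report more compounds than this note shows. Statements on the series, on what has been measured and on what is new or still open speak of the compounds shown alone.

Of the compounds shown here, three have been measured in an ADME assay on microsomes from liver (Rattus norvegicus) for metabolic stability; on this read-out higher numbers stand for fast clearance and lower numbers for slow clearance. Compound 1 `CNc1nc(C#N)nc(NC2(C#N)CCCCC2)n1` gives 122 mL/min/kg, the second highest of the three numbers. Compound 3 `CNc1nc(NC2(C#N)CCCCCC2)nc(-n2cncn2)n1` is the nearest to it and shows a higher number, 276 mL/min/kg, a gap beyond the usual scatter. The furthest from compound 1 is compound 2 `CCC(C)(C#N)Nc1nc(NC)nc(-n2cncn2)n1`, which shows a lower number, 32 mL/min/kg, again beyond the scatter. Among the compounds with values here, no single-point step between these measured compounds exists, since each pair differs in more than one place.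

Compound 4 `CNc1nc(NC2(C#N)CCCCC2)nc(-n2cnc(C#N)n2)n1` has not yet been measured. It differs from compound 1 in one place: 3-cyano-1H-1,2,4-triazol-1-yl in place of cyano on an aromatic carbon

Because compound 3 gives 276 mL/min/kg while carrying a triazole-type substituent on the core, the expectation for compound 4 is a modest step toward faster clearance, a 1.2-fold higher number from compound 1 to compound 4 (0.09 log units; within the scatter), that may still lie within the scatter. The estimated clearance of compound 4 in this assay is 150 mL/min/kg, with a range from 70 mL/min/kg to 330 mL/min/kg.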

Compound 4, clearance: 210 mL/min/kg
For compound 4 the middle estimate is 1.4-fold (0.15 log units) below the measured one; the measured number falls inside the stated range.
By their numbers in this assay, from the lowest: compound 2; then compounds 1, 4 and 3 (each within the scatter of the next, the first and the last beyond it).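

On the aromatic carbon between two ring nitrogen atoms, putting 3-cyano-1H-1,2,4-triazol-1-yl in place of cyano gives, in this assay, a 1.7-fold higher number from compound 1 to compound 4 (0.24 log units; within the scatter). Within the data shown here, this is the first comparison here that changes only one place, and it shows that a single small group and a far larger five-membered aromatic ring can occupy this position without a difference that can be told apart from the usual scatter. Nothing available explains this result or links it to any property of either group.

Going by these compounds, only these two groups can be compared at this position, so it remains open how a methoxy group or a carboxylic acid would read there. Also open, on these data alone, is whether the same swap would read alike with an ethylamino group in place of the methylamino group.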